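Swapping Cyclobutyl for Fluoro on the Aminopyrimidine Arm

The compounds below may be only part of what the source reports. "The series", "measured", "known", "first", "only" and "open" are said of these compounds alone.

Of the compounds shown here, three have been measured in a functional assay (aorta) with Oryctolagus cuniculus as the target; on this read-out higher numbers stand for weaker inhibition and lower numbers for stronger inhibition. Compound 1 `Fc1ccccc1Cn1nc(C2=NCCN2)c2cccnc21` gives 3200 nM in this assay. Compound 2 `CC(C)(C)c1cnc(-c2nn(Cc3ccccc3F)c3ncccc23)nc1N` gives 709000 nM, and compound 3 `Nc1nc(-c2nn(Cc3ccccc3F)c3ncccc23)ncc1C1CCC1` gives 633000 nM. Among the measured compounds shown here, compound 3 thus sits with compound 2 far from compound 1: the step of a 1.1-fold lower number from compound 2 to compound 3 (0.05 log units; within the scatter) is the only single-point comparison available, and it shows that cyclobutyl in place of tert-butyl on an aromatic carbon leaves the number essentially unchanged.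

Compound 4 `Nc1nc(-c2nn(Cc3ccccc3F)c3ncccc23)ncc1F` differs from compound 3 by fluoro in place of cyclobutyl on an aromatic carbon. For the measured compounds named here, the one measured step, a 1.1-fold lower number from compound 2 to compound 3 (0.05 log units; within the scatter), exchanged two carbon groups of similar bulk and did not move the number beyond the scatter; no measured step replaces a carbon ring by a single fluorine on that aromatic carbon, so the change has no direct precedent here. Given that compound 3 gives 633000 nM and that compound 2 gives 709000 nM, the expectation for compound 4 is a number near those two, with the step of a 1.3-fold lower number from compound 3 to compound 4 (0.10 log units; within the scatter) expected to stay within the scatter. Compound 4 is therefore estimated at 500000 nM, with a range from 100000 nM to 2000000 nM.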

Compound 4, half-maximal inhibitory concentration: 478000 nM
Compound 4: middle estimate off by 1.0-fold (0.02 log units), on the high side; measured number inside the range.
By their numbers in this assay, from the lowest: compound 1; then compounds 4, 3 and 2 (each within the scatter of the next).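

In this assay, fluoro in place of cyclobutyl gives a 1.3-fold lower number from compound 3 to compound 4 (0.12 log units; within the scatter) and fluoro in place of tert-butyl gives a 1.5-fold lower number from compound 2 to compound 4 (0.17 log units; within the scatter), so on this aromatic carbon a single fluorine and either carbon group cannot be told apart. Changing the group on this carbon therefore does not close the distance to compound 1, which stays large in the step of a 150-fold higher number from compound 1 to compound 4 (2.17 log units; beyond the scatter) and goes with the larger swap of the whole group on the aromatic carbon of the core. Nothing measured here explains why the number holds steady across these groups.

Going by these compounds, what an amine, a carboxylic acid or a longer chain on this aromatic carbon would do remains open. Also open, on these data alone, is how the amino group, ortho to this carbon, contributes to the high numbers of compounds 2, 3 and 4.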